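This account rests on a few compounds, and the source may have more. Where it says the series, first, only, none or still open, it means among the compounds named here.

Measured compounds in a functional assay on the whole organism for activation, with Mus musculus as the target; on this read-out higher numbers stand for an effect only at larger amounts of compound and lower numbers for an effect already at smaller amounts:
Compound 1, `Nc1ncnc2c1nc(O)n2Cc1ccc(Cl)cc1`: 30 mg/kg
Compound 2, `CCOc1nc(N)c2nc(O)n(Cc3ccccc3)c2n1`: 0.3 mg/kg
Compound 3, `Nc1ncnc2c1nc(S)n2Cc1ccccc1`: > 30 mg/kg, a limit of the assay

Of the two numbers obtained, compound 2 has the lower one; compound 1 sits at a higher number, and the gap lies well beyond the usual scatter. For compound 3 the assay gave only a limit, (the limit of > 30 mg/kg in this assay, at which 1 of the 3 values shown sits), and no number. These three compounds share one core, and the study now moves from compound 2 to compound 4, `CCCCCSc1nc(N)c2nc(O)n(Cc3ccccc3)c2n1`, which has not yet been measured in this assay.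

The change is pentylsulfanyl in place of ethoxy on an aromatic carbon. Pentylsulfanyl enters where ethoxy leaves, on an aromatic carbon of a six-membered aromatic ring with 2 nitrogen, part of a fused system of two rings. Among the measured compounds shown here, no pair of measured compounds shows what such a change does in this assay, so the expectation rests on compound 2 alone. The step from compound 2 to compound 4 is expected to be a modest rise in dose, a 3.3-fold higher number from compound 2 to compound 4 (0.52 log units; beyond the scatter), not clearly beyond the scatter. Compound 4 is therefore estimated at 1 mg/kg, with a range from 0.1 mg/kg to 10 mg/kg.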

Compound 4, minimum effective dose: 1 mg/kg
Compound 4: middle estimate and measured number agree at the digits printed; measured number inside the range.
By their numbers in this assay, from the lowest: compound 2; then compound 4; then compound 1.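

In this assay the aromatic carbon between two ring nitrogen atoms takes a much larger group with only a limited cost: pentylsulfanyl, with 6 heavy atoms against the 3 of ethoxy, gives a 3.3-fold higher number from compound 2 to compound 4 (0.52 log units; beyond the scatter) and so leaves compound 4 active at a low dose. Among the compounds shown here, this is the first measured change at this carbon, as the earlier compounds offered no pair differing in one place, and it shows that an oxygen-linked short chain is not required here for activity in the whole animal. For the compounds shown here, the single step changes both the chain length and the linking atom, and nothing measured here bears on the cause of the step.

The compounds shown leave open how much of the step belongs to the sulfur and how much to the longer chain, a question that pentyloxy or ethylsulfanyl at this carbon would separate. Also open, from the compounds shown here alone, is how far this carbon's tolerance extends, for instance to a chain longer than pentyl, an amine or a carboxylic acid.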